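Anilino trimming in the series: compound 3 to compound 4

The compounds below may be only part of what the source reports. "The series", "measured", "known", "first", "only" and "open" are said of these compounds alone.

The series shares one core and varies only the anilino group. In a functional assay on NCI-H1975 cells (Homo sapiens) for antiproliferative activity, read by MTT assay, with a stated time of 72 h (a lower number here means a stronger inhibitor, a higher number a weaker inhibitor), compound 1 `COc1cc2ncnc(Nc3ccc(Cl)c(C(F)(F)F)c3)c2cc1OCCCCC(=O)Nc1ccc(S(N)(=O)=O)cc1` gives 3220 nM. Compound 2 `COc1cc2ncnc(Nc3cccc(Cl)c3)c2cc1OCCCCC(=O)Nc1ccc(S(N)(=O)=O)cc1` gives 33200 nM in this assay, and compound 3 `COc1cc2ncnc(Nc3ccc(F)c(Br)c3)c2cc1OCCCCC(=O)Nc1ccc(S(N)(=O)=O)cc1` gives 31600 nM. Compound 3 thus stands second highest of the three numbers: against compound 2 the difference is within the scatter (a 1.1-fold lower number from compound 2 to compound 3 (0.02 log units; within the scatter)), while against compound 1 the gap is clear (a 9.8-fold higher number from compound 1 to compound 3 (0.99 log units; beyond the scatter)).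

Compound 4 `COc1cc2ncnc(Nc3ccccc3)c2cc1OCCCCC(=O)Nc1ccc(S(N)(=O)=O)cc1` differs from compound 3 by phenyl in place of 3-bromo-4-fluorophenyl on a nitrogen on an aromatic ring. Among the measured compounds shown here, two measured steps bear on it. The steps of a 10-fold higher number from compound 1 to compound 2 (1.01 log units; beyond the scatter) and a 9.8-fold higher number from compound 1 to compound 3 (0.99 log units; beyond the scatter) show that losing the trifluoromethyl group comes with a large step upward, whereas a 1.1-fold lower number from compound 2 to compound 3 (0.02 log units; within the scatter) shows that swapping one halogen pattern for another gives nothing beyond the scatter. For the measured compounds named here, no measured step removes every ring substituent, so the effect of going to bare phenyl is not directly covered. Stripping the remaining bromine and fluorine is expected to give no more than a small step upward in this assay. For compound 4 the expected value is 45000 nM, within a range from 15000 nM to 130000 nM, an estimated step of a 1.4-fold higher number from compound 3 to compound 4 (0.15 log units; within the scatter).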

Compound 4, half-maximal inhibitory concentration: 14100 nM
Estimate against measurement, compound 4: 3.2-fold (0.50 log units) above; the whole stated range lies above it.
By their numbers in this assay, from the lowest: compound 1; then compound 4; then compounds 3 and 2 (each within the scatter of the next).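

In this assay, stripping the anilino ring of its halogens does not raise the number: a 2.2-fold lower number from compound 3 to compound 4 (0.35 log units; beyond the scatter) and a 2.4-fold lower number from compound 2 to compound 4 (0.37 log units; beyond the scatter), so bare phenyl on this nitrogen goes with a lower number than either the 3-bromo-4-fluorophenyl or the 3-chlorophenyl group. Of the substituted rings shown, only the 4-chloro-3-(trifluoromethyl)phenyl group stands below bare phenyl, a 4.4-fold higher number from compound 1 to compound 4 (0.64 log units; beyond the scatter), so a substituent at this place can go with either a higher or a lower number than hydrogen, with compound 1 going against compound 2 and compound 3. Nothing available gives a reason for these differences.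

From the compounds shown here alone, whether the chloro or the trifluoromethyl group alone would keep the lower number of compound 1 stays open. Going by these compounds, how an amine or a methoxy group on the phenyl ring would compare also stays open.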